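This account rests on a few compounds, and the source may have more. Where it says the series, first, only, none or still open, it means among the compounds named here.

Three compounds share one core and differ only in a single group on an aromatic carbon. Compound 1 `CC1(C)Oc2ccc(Cc3ccccc3)cc2[C@@H](/N=C(\NC#N)Nc2ccc(Cl)cc2)[C@@H]1O` carries a benzyl group there, and in a functional assay (aorta) with Rattus norvegicus as the target (on this read-out lower numbers stand for stronger inhibition and higher numbers for weaker inhibition), compound 1 gives 10000 nM. Compound 2 `CC(C)(C)C(=O)c1ccc2c(c1)[C@@H](/N=C(\NC#N)Nc1ccc(Cl)cc1)[C@H](O)C(C)(C)O2` carries a (tert-butyl)carbonyl group; in this assay compound 2 gives 5400 nM, the lowest of the two plain numbers, although the step of a 1.9-fold lower number from compound 1 to compound 2 (0.27 log units; within the scatter) stays within the scatter. Compound 3 `CC1(C)Oc2ccc(C(=O)Nc3ccccc3)cc2[C@@H](/N=C(\NC#N)Nc2ccc(Cl)cc2)[C@@H]1O` carries a phenylcarbamoyl group. In this assay compound 3 gives > 100000 nM, which is a limit of the measurement rather than a number, namely (the limit of > 100000 nM in this assay, at which 1 of the 3 values shown sits). From that follow the steps of an at least 18-fold higher number from compound 2 to compound 3 (1.26 log units; beyond the scatter) and an at least 10-fold higher number from compound 1 to compound 3 (1.00 log units; beyond the scatter).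

Compound 4 `CC1(C)Oc2ccc(S(N)(=O)=O)cc2[C@@H](/N=C(\NC#N)Nc2ccc(Cl)cc2)[C@@H]1O` differs from compound 2 by sulfamoyl in place of (tert-butyl)carbonyl on an aromatic carbon. Going by the values given here, two measured steps bear on this: exchanging benzyl for a carbonyl group changed little in a 1.9-fold lower number from compound 1 to compound 2 (0.27 log units; within the scatter), whereas moving from the ketone to the amide weakened inhibition strongly in an at least 18-fold higher number from compound 2 to compound 3 (1.26 log units; beyond the scatter). Removing the ketone altogether is therefore expected to weaken inhibition, as the step of a 5.6-fold higher number from compound 2 to compound 4 (0.74 log units; beyond the scatter). Compound 4 is estimated at 30000 nM, with a range from 8000 nM to 100000 nM.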

Compound 4, half-maximal inhibitory concentration: 41300 nM
Compound 4: middle estimate off by 1.4-fold (0.14 log units), on the low side; measured number inside the range.
By their numbers in this assay, from the lowest: compounds 2 and 1 (each within the scatter of the next); then compound 4. At a limit, above all of these: compound 3.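

Against both earlier groups on this aromatic carbon, sulfamoyl weakens inhibition in this assay: a 7.6-fold higher number from compound 2 to compound 4 (0.88 log units; beyond the scatter), and a 4.1-fold higher number from compound 1 to compound 4 (0.62 log units; beyond the scatter). Yet it gives a plain number where phenylcarbamoyl does not, with an at least 2.4-fold lower number from compound 3 to compound 4 (0.38 log units; beyond the scatter), so a change at this position can now be seen to have an intermediate outcome, not only a small or a large one. The value for compound 3 is a limit, so the true size of this last step stays unknown: the limit of > 100000 nM in this assay, at which 1 of the 4 values shown sits.

The compounds shown leave open whether a small group on this carbon, such as a methyl, an amine or a carboxylic acid, would sit nearer compound 2 or compound 4. They also leave open whether a methylsulfonyl group, which has no nitrogen, would behave like sulfamoyl.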